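The source may hold more compounds than are shown below. What is called first, only, known or untested is meant among the compounds shown, and "the series" means these compounds.

Measured so far in an in vitro functional assay on HEK285-7 cells for antagonist activity at prostaglandin D2 receptor 2 (Homo sapiens), read by BRET and beta-arrestin recruitment; on this read-out higher numbers stand for weaker inhibition and lower numbers for stronger inhibition:

compound 1 `O=C(O)Cc1sc(C(c2ccccc2)c2ccc(F)cc2)nc1-c1ccc(Cl)cc1`: 36 nM
compound 2 `O=C(O)Cc1sc(C(c2ccc(F)cc2)c2ccc(F)cc2)nc1-c1ccc(Cl)cc1`: 180 nM
compound 3 `O=C(O)Cc1sc(C(c2ccccc2)c2ccc(Cl)cc2)nc1-c1ccc(F)cc1`: 79 nM

Compound 2 gives the highest number of the three; compound 3 stands nearest to it and compound 1 furthest, both steps beyond the scatter.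

Compound 4 `O=C(O)Cc1sc(C(c2ccc(F)cc2)c2ccc(F)cc2)nc1-c1cn[nH]c1` differs from compound 2 in one place: 1H-pyrazol-4-yl in place of 4-chlorophenyl on an aromatic carbon.

Among the measured compounds shown here, the only single-site step in hand, a 5.0-fold higher number from compound 1 to compound 2 (0.70 log units; beyond the scatter), concerns a different aryl and gives no guide to this exchange. For the measured compounds named here, compounds 1 and 3 differ in two places, so their values yield no single step either. Going by the values given here, no measured pair bears on the change to 1H-pyrazol-4-yl, and no direction can be drawn from the data.

Compound 4 is therefore estimated at 300 nM, with a wide range of 60 nM to 1500 nM. Against compound 2, the estimate for compound 4 means an expected step of a 1.7-fold higher number from compound 2 to compound 4 (0.22 log units; within the scatter).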

Compound 4, half-maximal inhibitory concentration: 220 nM
The estimate for compound 4 lay 1.4-fold (0.13 log units) above the measured number, and the stated range covers the measured number.
By their numbers in this assay, from the lowest: compound 1; then compound 3; then compounds 2 and 4 (each within the scatter of the next).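

Position notes: in this assay, the aromatic carbon next to the ring nitrogen accepts a five-membered aromatic ring with 2 hetero atoms in place of a six-membered aromatic ring of carbon only, giving a 1.2-fold higher number from compound 2 to compound 4 (0.09 log units; within the scatter). On this read-out, the exchange of 4-chlorophenyl for 1H-pyrazol-4-yl, which introduces a hydrogen-bond donor and acceptor, therefore shows no step beyond the scatter. No supporting measurement explains this outcome.

On these data alone, open: whether the same exchange holds on the core of compound 1, which carries one unsubstituted phenyl, remains unknown. Also unknown is how a pyridin-4-yl or an aliphatic amine would read at this position.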